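Exchanging the Amine Substituent on a Shared Core

This account rests on a few compounds, and the source may have more. Where it says the series, first, only, none or still open, it means among the compounds named here.

Of the compounds shown here, two built on one shared core have been tested in a functional assay on HGC-27 cells (Homo sapiens) for cytotoxicity, read by MTT assay, with a stated time of 72 h; a lower number here means a stronger inhibitor, a higher number a weaker inhibitor. Compound 1 `CCCCCCCCCCCCNc1nc(SCc2ccc(C(F)(F)F)cc2)nc2ccccc12` gives 38700 nM. Compound 2 `Cc1ccccc1Nc1nc(SCc2ccc(C(F)(F)F)cc2)nc2ccccc12` gives 27500 nM. These two numbers lie within the scatter of each other, so compound 2 cannot be set apart from compound 1 on the evidence at hand.

Compound 3 `FC(F)(F)c1ccc(CSc2nc(Nc3ccc(C(F)(F)F)cc3)c3ccccc3n2)cc1` differs from compound 2 in one place: 4-(trifluoromethyl)phenyl in place of 2-methylphenyl on a nitrogen on an aromatic ring. Going by the values given here, no measured pair shows this particular exchange, so its effect is not known from the data. Because compound 1 at 38700 nM and compound 2 at 27500 nM carry very different groups on that nitrogen and still fall within the scatter, the step is expected to be small, a 1.3-fold lower number from compound 2 to compound 3 (0.10 log units; within the scatter), with no clear direction beyond the scatter. Compound 3 is therefore estimated at 22000 nM, within a range from 7000 nM to 70000 nM.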

Compound 3, half-maximal inhibitory concentration: 7560 nM
Estimate against measurement, compound 3: 2.9-fold (0.46 log units) above; the measured number falls inside the stated range.
By their numbers in this assay, from the lowest: compound 3; then compounds 2 and 1 (each within the scatter of the next).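

In this assay, replacing 2-methylphenyl with 4-(trifluoromethyl)phenyl on the nitrogen gives a 3.6-fold lower number from compound 2 to compound 3 (0.56 log units; beyond the scatter). This shows that the number does respond to the group at this position, something the values of compound 1 and compound 2, which lie within the scatter of each other, could not show. No measurement at hand accounts for the lower number of compound 3.

The exchange removes one group and adds another at a different place on the phenyl ring, so the compounds shown cannot separate the loss of the 2-methyl group from the gain of the 4-trifluoromethyl group. Plain phenyl, 4-methylphenyl and 2-(trifluoromethyl)phenyl on the same nitrogen would be the groups to tell these contributions apart.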